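A few compounds are considered here, and "the series" means these few. Any claim that something is new, unique, unknown or untested is made for them only; others in the source may bear on it.

Of the compounds shown here, three built on a shared core have been measured so far. Compound 1 `COc1cc(-c2cc(/C=C/C(=O)c3ccc(N)cc3)[nH]n2)cc(OC)c1OC` gives -57% in a functional assay on MCF7 cells (Homo sapiens) for cytotoxicity, read by sulforhodamine B assay, with a stated time of 48 h, tested at 100 uM; a higher number here means a weaker effect of the compound at the concentration tested, a lower number a stronger effect. Compound 2 `COc1ccc(C(=O)/C=C/c2cc(-c3cc(OC)c(OC)c(OC)c3)n[nH]2)cc1OC` gives -66% in this assay, and compound 3 `COc1ccc(C(=O)/C=C/c2cc(-c3cc(OC)c(OC)c(OC)c3)n[nH]2)cc1` gives -69%. Compound 3 therefore stands lowest of the three numbers: its nearest neighbour is compound 2, a gap that lies within the scatter, while compound 1 lies furthest from it, a gap that lies beyond the scatter.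

Compound 4 `COc1cc(-c2cc(/C=C/C(=O)c3ccc(F)c(F)c3)[nH]n2)cc(OC)c1OC` differs from compound 3 in one place: 3,4-difluorophenyl in place of 4-methoxyphenyl on a carbonyl carbon.

For the measured compounds named here, three measured steps bear on the aryl group attached to the carbonyl carbon. The step of a number 9 percentage points lower from compound 1 to compound 2 (within the scatter) and the step of a number 3 percentage points lower from compound 2 to compound 3 (within the scatter) both swapped substituents on that ring and stayed within the scatter, while a number 12 percentage points lower from compound 1 to compound 3 (beyond the scatter) was modest but beyond it. The ring on the carbonyl carbon thus appears tolerant of exchange among the few variants seen, though nothing measured yet covers a ring bearing fluorine. Compound 4 is therefore expected to land close to compound 3, with a number 4 percentage points higher from compound 3 to compound 4 (within the scatter) expected to fall within the scatter. Compound 4 is estimated to give -65% in this assay, within a range from -85% to -45%.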

Compound 4, a percentage reported as activity, at one concentration (the size of the read-out at that concentration, not a potency): -20%
For compound 4 the middle estimate is 45 percentage points below the measured one, and the stated range ends below it.
By their numbers in this assay, from the lowest: compounds 3, 2 and 1 (each within the scatter of the next, the first and the last beyond it); then compound 4.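

For the compounds shown here, the ring on the carbonyl carbon proves less tolerant than the earlier compounds suggested: in this assay, 3,4-difluorophenyl in place of 4-methoxyphenyl gives a number 49 percentage points higher from compound 3 to compound 4 (beyond the scatter) and marks the first large step at this position. The same exchange starting from 3,4-dimethoxyphenyl gives a number 46 percentage points higher from compound 2 to compound 4 (beyond the scatter) and starting from 4-aminophenyl gives a number 37 percentage points higher from compound 1 to compound 4 (beyond the scatter), so the fluorinated ring stands apart from all three earlier rings, among which the widest step was only a number 12 percentage points lower from compound 1 to compound 3 (beyond the scatter) in the same assay. No measurement at hand accounts for this loss of effect at the concentration tested.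

The compounds shown leave open whether the loss follows from fluorine itself or from having two halogens on the ring, a question that a phenyl bearing a single fluorine, a dichlorophenyl or an unsubstituted phenyl on the carbonyl carbon would bear on. They also leave open how the three compounds with the stronger effect at the concentration tested would compare at other concentrations, since each read-out comes from one concentration only.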